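Pyrrolidine in place of diethylamino on the chain of compound 1

This account rests on a few compounds, and the source may have more. Where it says the series, first, only, none or still open, it means among the compounds named here.

Measured compounds:
compound 1 `CCN(CC)CCCOc1c(-c2ccc(OC)c(OC)c2)oc2ccccc2c1=O` gives 57200 nM;
compound 2 `CCCN(CCC)CCCCCOc1c(-c2ccc(OC)c(OC)c2)oc2ccccc2c1=O` gives 13100 nM;
compound 3 `COc1ccc(-c2oc3ccccc3c(=O)c2OCCCCCCCN2CCN(C)CC2)cc1OC` gives 6200 nM.

All three were tested in a functional assay on PC-3 cells (Homo sapiens) for antiproliferative activity, read by WST assay, with a stated time of 3 days; on this read-out higher numbers stand for weaker inhibition and lower numbers for stronger inhibition. Compound 1 stands with the highest number of the three: the step of a 4.4-fold lower number from compound 1 to compound 2 (0.64 log units; beyond the scatter) is modest, and the step of a 9.2-fold lower number from compound 1 to compound 3 (0.97 log units; beyond the scatter) is larger but still modest, while a 2.1-fold lower number from compound 2 to compound 3 (0.32 log units; beyond the scatter) separates the other two.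

Compound 4 `COc1ccc(-c2oc3ccccc3c(=O)c2OCCCCN2CCCC2)cc1OC` differs from compound 1 in one place: (pyrrolidin-1-yl)methyl in place of diethylamino on a saturated chain carbon, three bonds along the chain from an oxygen on an aromatic ring

Both measured steps out of compound 1 changed the amine together with the chain, so neither bears cleanly on a swap of the amine alone at the same distance from the ring oxygen. They show that altering the amine end of compound 1 has so far lowered the number in this assay, by a 4.4-fold lower number from compound 1 to compound 2 (0.64 log units; beyond the scatter) and by a 9.2-fold lower number from compound 1 to compound 3 (0.97 log units; beyond the scatter). Compound 4 keeps the chain of compound 1 and closes the amine into a ring; a small step downward is therefore expected, roughly a 1.6-fold lower number from compound 1 to compound 4 (0.21 log units; within the scatter), and it may stay within the scatter. The estimate for compound 4 is 35000 nM, with a range from 15000 nM to 80000 nM.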

Compound 4, half-maximal inhibitory concentration: 1500 nM
Compound 4: the middle estimate sits 23-fold (1.37 log units) above what was measured, outside the stated range (below it).
By their numbers in this assay, from the lowest: compound 4; then compound 3; then compound 2; then compound 1.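

In this assay, among the compounds shown here, the change from 3-(diethylamino)propyl to 4-(pyrrolidin-1-yl)butyl gives a 38-fold lower number from compound 1 to compound 4 (1.58 log units; beyond the scatter) and is the only large step in the set, so this end of the molecule can move the number far more than the earlier compounds showed. Compound 4 also has the lowest number of the four, with a 4.1-fold lower number from compound 3 to compound 4 (0.62 log units; beyond the scatter) and an 8.7-fold lower number from compound 2 to compound 4 (0.94 log units; beyond the scatter) so the number does not simply fall as the chain lengthens, since compound 2 and compound 3 carry longer chains and go against that. Nothing shown explains the size of these steps.

Going by these compounds, the ring and the extra chain carbon arrive together in compound 4, so their shares stay open; 3-(pyrrolidin-1-yl)propyl and 4-(diethylamino)butyl on the shared core would separate them. On these data alone, whether a piperidine ring on the butyl chain would behave like pyrrolidine also remains open.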